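Moving the nitro group around the anilino ring

This account rests on a few compounds, and the source may have more. Where it says the series, first, only, none or still open, it means among the compounds named here.

Compound 1 `CCOc1ccc(Cl)cc1-c1cc(Nc2ccc(Cl)cc2)nc(N)n1` and compound 2 `CCOc1ccc(Cl)cc1-c1cc(Nc2ccc([N+](=O)[O-])cc2)nc(N)n1` share a core and differ only in the group on one aromatic carbon. In a functional assay on K562 cells (Homo sapiens) for inhibition (a higher number here means a weaker inhibitor, a lower number a stronger inhibitor), compound 1 reaches only the limit < 12 nM (the limit of < 12 nM in this assay, at which 1 of the 2 values shown sits). In this assay compound 2 gives 180 nM, the only number shown so far; the step of an at least 15-fold higher number from compound 1 to compound 2 (1.17 log units; beyond the scatter) is large. Compound 3 `CCOc1ccc(Cl)cc1-c1cc(Nc2cccc([N+](=O)[O-])c2)nc(N)n1` keeps the nitro group but shifts it: 3-nitrophenyl in place of 4-nitrophenyl on a nitrogen on an aromatic ring. Among the measured compounds shown here, no measured step bears on such a shift, so for compound 3 in this assay a change within the scatter is expected, a 1.1-fold higher number from compound 2 to compound 3 (0.05 log units; within the scatter), giving an estimate of 200 nM with a range from 60 nM to 700 nM.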

Compound 3, half-maximal inhibitory concentration: 450 nM
Compound 3: middle estimate off by 2.3-fold (0.35 log units), on the low side; low and high end bracket the measured number.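

Where the nitro group sits on the ring matters in this assay: 3-nitrophenyl in place of 4-nitrophenyl gives a 2.5-fold higher number from compound 2 to compound 3 (0.40 log units; beyond the scatter). Set against the 4-chlorophenyl group, 3-nitrophenyl gives an at least 37-fold higher number from compound 1 to compound 3 (1.57 log units; beyond the scatter), so this step is larger than the shift of the nitro group. Compound 1 stands at a limit of the assay, not at a number: the limit of < 12 nM in this assay, at which 1 of the 3 values shown sits.

Going by these compounds, how a 3-aminophenyl or a 4-carboxyphenyl group would read on the same nitrogen stays open. So does whether 3-chlorophenyl in place of 4-chlorophenyl would give a step like that of the nitro pair.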